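Swapping the Hydrazone Aryl Group on a Methoxy Core

A few compounds are considered here, and "the series" means these few. Any claim that something is new, unique, unknown or untested is made for them only; others in the source may bear on it.

Compound 1 `O=C(N/N=C/c1cc(Br)c(O)c(Br)c1)Nc1cc2c(Nc3ccc(F)c(Cl)c3)ncnc2cc1O[C@H]1CCOC1` and compound 2 `O=C(N/N=C/c1ccc(O)cc1O)Nc1cc2c(Nc3ccc(F)c(Cl)c3)ncnc2cc1O[C@H]1CCOC1` share one core and differ only in the aryl group carried on the carbon with a double bond to nitrogen. In a functional assay on MCF7 cells (Homo sapiens) for cytotoxicity, read by MTT assay, with a stated time of 72 h (on this read-out higher numbers stand for weaker inhibition and lower numbers for stronger inhibition), compound 1 gives 5910 nM and compound 2 gives 5350 nM. The change between them is 2,4-dihydroxyphenyl in place of 3,5-dibromo-4-hydroxyphenyl on a carbon with a double bond to nitrogen and it made a step of a 1.1-fold lower number from compound 1 to compound 2 (0.04 log units; within the scatter). Compound 3 `COc1cc2ncnc(Nc3ccc(F)c(Cl)c3)c2cc1NC(=O)N/N=C/c1cc(Br)c(O)c(Br)c1` has a different core; the difference is methyl in place of oxolan-3-yl on an oxygen on an aromatic ring, and that change made a step of a 5.1-fold higher number from compound 1 to compound 3 (0.71 log units; beyond the scatter). In this assay compound 3 gives 30200 nM. Compound 4 `COc1cc2ncnc(Nc3ccc(F)c(Cl)c3)c2cc1NC(=O)N/N=C/c1ccc(O)cc1O` has not yet been measured. It relates to compound 3 exactly as compound 2 relates to compound 1: the change is 2,4-dihydroxyphenyl in place of 3,5-dibromo-4-hydroxyphenyl on a carbon with a double bond to nitrogen, at the same place, so it is the same change carried onto the core of compound 3. Because the earlier step of a 1.1-fold lower number from compound 1 to compound 2 (0.04 log units; within the scatter) stayed within the scatter, a similarly small step is expected this time, a 1.1-fold lower number from compound 3 to compound 4 (0.05 log units; within the scatter). Compound 4 is therefore expected to give 27000 nM in this assay, with a plausible range from 11000 nM to 70000 nM.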

Compound 4, half-maximal inhibitory concentration: 36200 nM
Beside the measured number, compound 4's estimate is 1.3-fold (0.13 log units) below it, and the stated range covers the measured number.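

Putting 2,4-dihydroxyphenyl in place of 3,5-dibromo-4-hydroxyphenyl on the core of compound 3 made a 1.2-fold higher number from compound 3 to compound 4 (0.08 log units; within the scatter) in this assay, so this change carried over to the second core as a step too small to read: the same change on two cores in this assay, a 1.1-fold lower number (0.04 log units; within the scatter) from compound 1 to compound 2 and a 1.2-fold higher number (0.08 log units; within the scatter) from compound 3 to compound 4, 1.3-fold (0.12 log units) apart, within the scatter of two such steps

Methyl in place of oxolan-3-yl, read this time with the 2,4-dihydroxyphenyl group present, made a 6.8-fold higher number from compound 2 to compound 4 (0.83 log units; beyond the scatter), and this larger step also held its size: the same change on two cores in this assay, a 5.1-fold higher number (0.71 log units; beyond the scatter) from compound 1 to compound 3 and a 6.8-fold higher number (0.83 log units; beyond the scatter) from compound 2 to compound 4, 1.3-fold (0.12 log units) apart, within the scatter of two such steps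

Within these compounds, then, the two changes appear to act independently of each other, but that rests on only two aryl groups, two groups on the oxygen and one cell assay, so it shows neither that the pattern extends to other groups or cores nor why the numbers move.

Still open, on these data alone, is whether an aryl group carrying an amine or a carboxylic acid would also leave the number unchanged. Also open, as far as these compounds go, is whether a longer chain on the oxygen would give a number closer to that of methyl or of oxolan-3-yl.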